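A few compounds are considered here, and "the series" means these few. Any claim that something is new, unique, unknown or untested is made for them only; others in the source may bear on it.

Compound 1 `CN1CCN(c2nc(-c3cccc(Cl)c3)nc3[nH]cnc23)CC1` gives 100 nM in an assay on cells for displacement of a labelled ligand from adenosine receptor A3 (Homo sapiens), read by scintillation counting and radioligand binding, with a stated time of 180 min; a lower number here means a stronger inhibitor, a higher number a weaker inhibitor. Compound 2 `Clc1ccc(-c2nc(N3CCCCC3)c3nc[nH]c3n2)cc1` gives 7.94 nM. Compound 3 `CN1CCN(c2nc(-c3ccc(Cl)c(C(F)(F)F)c3)nc3[nH]cnc23)CC1` gives 794 nM.

Among these three numbers compound 1 sits second highest: compound 3 lies well above it and compound 2 well below it, and both gaps are beyond the scatter. Compound 4 `CN1CCN(c2nc(-c3cccc(O)c3)nc3[nH]cnc23)CC1` has not been measured yet. It differs from compound 1 in a single place: hydroxy in place of chloro on an aromatic carbon. For the measured compounds named here, no pair of measured compounds shows this same change, so nothing here can anchor its effect directly. The step is expected to be a moderate weakening, estimated as a 3.0-fold higher number from compound 1 to compound 4 (0.48 log units; beyond the scatter). For compound 4 the expected value in this assay is 300 nM, with a likely range from 60 nM to 1500 nM.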

Compound 4, inhibition constant: 501 nM
Compound 4: middle estimate off by 1.7-fold (0.22 log units), on the low side; measured number inside the range.
By their numbers in this assay, from the lowest: compound 2; then compound 1; then compounds 4 and 3 (each within the scatter of the next).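

In this assay, replacing chloro with hydroxy on the aromatic ring gives a 5.0-fold higher number from compound 1 to compound 4 (0.70 log units; beyond the scatter). For the compounds shown here, this is the first single change that can be read on its own, since no earlier pair differed in just one place, and it shows that the group at this position matters, with chloro the better of the two here. Nothing available explains the step.

Going by these compounds, whether other groups here, such as methoxy, fluoro or an amine, would behave like chloro or like hydroxy stays open. So does whether the same swap would have a similar effect in a different compound.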